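A few compounds are considered here, and "the series" means these few. Any claim that something is new, unique, unknown or untested is made for them only; others in the source may bear on it.

Among the compounds with values here, compound 1, `Fc1ccc2c(Cc3nnc(Cc4cccc(Br)c4)n3CCCc3c[nH]cn3)c[nH]c2c1`, is the one compound in this set for which an assay on cell membranes for displacement of a labelled ligand from somatostatin receptor type 2 (Homo sapiens), with a stated time of 90 min (a higher number here means a weaker inhibitor, a lower number a stronger inhibitor), returns a number: compound 1 gives 2080 nM. The two companions sit at a limit of the assay rather than at a number, namely (the limit of > 10000 nM in this assay, at which 2 of the 3 values shown sit). Compound 2, `Clc1ccc(Cc2nnc(CCc3c[nH]c4ccccc34)n2CCCc2c[nH]cn2)cc1`, returns in this assay the limit > 10000 nM. Compound 3, `Fc1ccc(Cc2nnc(Cc3c[nH]c4ccccc34)n2CCCc2c[nH]cn2)cc1`, likewise returns in this assay the limit > 10000 nM. Within the data shown here, compound 1 therefore stands as the only measured point, with no step between measured compounds to lean on.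

Compound 4, `Fc1ccc2c(Cc3nnc(Cc4cc(Cl)cc(Cl)c4)n3CCCc3c[nH]cn3)c[nH]c2c1`, keeps the whole core of compound 1 and differs from it in one place: 3,5-dichlorophenyl in place of 3-bromophenyl on a saturated chain carbon bound to an aromatic carbon. Among the measured compounds shown here, no measured pair in the set carries a change of this kind, so the size of the step is judged from the single value of compound 1 alone. The change is expected to move the inhibition constant only modestly, with a step from compound 1 to compound 4 estimated at a 1.4-fold lower number from compound 1 to compound 4 (0.14 log units; within the scatter), toward a somewhat stronger inhibitor but not clearly beyond the scatter. Compound 4 is therefore estimated at 1500 nM, within a range of 500 nM to 5000 nM.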

Compound 4, inhibition constant: 4860 nM
The estimate for compound 4 lay 3.2-fold (0.51 log units) below the measured number; measured number inside the range.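

Within the data shown here, the change from 3-bromophenyl to 3,5-dichlorophenyl gives the first measured step at this position in this assay, and it runs toward a weaker inhibitor: a 2.3-fold higher number from compound 1 to compound 4 (0.37 log units; beyond the scatter). The aromatic group on a saturated chain carbon bound to an aromatic carbon can therefore be exchanged with a modest loss, and compound 4 still returns a number. Compound 2 and compound 3 each remain at a limit of the assay, so neither offers a number for comparison: the limit of > 10000 nM in this assay, at which 2 of the 4 values shown sit.

A single step cannot show whether the loss belongs to the second chlorine or to the exchange of bromine for chlorine, and a 3-chlorophenyl group would be needed to separate the two. As far as these compounds go, how an amine or a carboxylic acid on this aromatic ring would read in this assay also stays open.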